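Dropping the chloro from the weak end of the series

The compounds below may be only part of what the source reports. "The series", "measured", "known", "first", "only" and "open" are said of these compounds alone.

In a functional assay on the whole organism for inhibition, with Cavia porcellus as the target (a lower number here means that less compound is needed, a higher number that more compound is needed for the effect), compound 1 `CN(C)/C(=N\C#N)C1=CC(C)(C)Oc2ccc(S(=O)(=O)c3ccccc3)cc21` gives 3630 nM and compound 2 `CN(C)/C(=N\C#N)C1=CC(C)(C)Oc2ccc(C(F)(F)F)cc21` gives 178 nM, a change of a 20-fold lower number from compound 1 to compound 2 (1.31 log units; beyond the scatter). Compound 3 `CN(C)/C(=N\C#N)C1=CC(C)(C)Oc2ccc(Cl)cc21` reaches only a limit, > 31600 nM. Compound 4 `CN(C)/C(=N\C#N)C1=CC(C)(C)Oc2ccccc21` differs from compound 3 by hydrogen in place of chloro on an aromatic carbon. Going by the values given here, no measured step replaces a group with hydrogen. The nearest evidence is two exchanges of group on an aromatic carbon, an at least 170-fold higher number from compound 2 to compound 3 (2.24 log units; beyond the scatter) and an at least 8.7-fold higher number from compound 1 to compound 3 (0.93 log units; beyond the scatter), both beyond the scatter. Since compound 3 stands at the limit > 31600 nM, only a small step in this assay is expected, possibly none beyond the scatter, with no firm direction. The expected change is a step that the limit leaves unreadable from compound 3 to compound 4. Compound 4 is estimated at 35000 nM, with an expected range of 10000 nM to 100000 nM.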

Compound 4, half-maximal effective concentration: > 31600 nM
Compound 4: a limit, no number (the forecaster's own chance of this, stated with the estimate: 65%); the middle value is on the limit's open side.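

In this assay compound 4 gives > 31600 nM, a limit and not a number. The steps between compound 3 and compound 4 cannot be read, as both compounds sit at the same limit: the limit of > 31600 nM in this assay, at which 2 of the 4 values shown sit. With hydrogen on this aromatic carbon, the readable steps are an at least 170-fold higher number from compound 2 to compound 4 (2.24 log units; beyond the scatter) and an at least 8.7-fold higher number from compound 1 to compound 4 (0.93 log units; beyond the scatter), so among these four groups only trifluoromethyl and phenylsulfonyl give a value short of the limit.

No order between chloro and hydrogen can be given. As far as these compounds go, whether an amine or a carboxylic acid on this carbon would also give a measurable value remains open.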